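Swapping a pyridyl for methyl: expected permeability shift

This account rests on a few compounds, and the source may have more. Where it says the series, first, only, none or still open, it means among the compounds named here.

Within the data shown here, compound 1 `CCCCc1nc(=O)c(S(=O)(=O)c2ccc(-c3cccnc3)cc2)c(O)n1-c1c(OC)cccc1OC` is one of two compounds measured so far. In an ADME assay for permeability, using PAMPA, at pH 5.5 (on this read-out higher numbers stand for higher permeability and lower numbers for lower permeability), compound 1 gives 202 nm/s. Compound 2 `CCCCc1[nH]c(=O)c(S(=O)(=O)c2ccc(-c3ccncc3C)cc2)c(O)c1-c1c(OC)cccc1OC` gives 355 nm/s in this assay, and the gap between the two numbers is within the usual scatter of repeated measurements, so compound 1 stands as the lower of two numbers without a real difference between them.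

Compound 3 `CCCCc1nc(=O)c(S(=O)(=O)c2ccc(C)cc2)c(O)n1-c1c(OC)cccc1OC` is not yet measured. It differs from compound 1 in one place: methyl in place of pyridin-3-yl on an aromatic carbon. Among the measured compounds shown here, no pair of measured compounds shows this change, so there is no measured step to lean on. The expectation for this assay is a small step, most likely not beyond the scatter, leaning slightly upward, as a 1.4-fold higher number from compound 1 to compound 3 (0.16 log units; within the scatter) expresses. Compound 3 is therefore estimated at 290 nm/s, with a plausible range from 120 nm/s to 700 nm/s.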

Compound 3, apparent permeability: 243 nm/s
Compound 3: middle estimate off by 1.2-fold (0.08 log units), on the high side; measured number inside the range.
By their numbers in this assay, from the lowest: compounds 1, 3 and 2 (each within the scatter of the next).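

Among these compounds, the step for methyl in place of pyridin-3-yl, on an aromatic carbon para to a large group, is a 1.2-fold higher number from compound 1 to compound 3 (0.08 log units; within the scatter) in this assay and gives the first direct reading of this position. A whole six-membered aromatic ring with 1 hetero atom leaves and only methyl enters, yet this read-out does not separate compound 1 from compound 3. No measured property of these groups is available to explain this result.

From the compounds shown here alone, with a single pair at this position, it remains open whether an amine, a carboxylic acid or a longer chain there would also stay within the scatter of compound 1. Going by these compounds, it is also open whether the same swap would read alike on the core of compound 2, which differs from compound 1 in more than one place.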